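This account rests on a few compounds, and the source may have more. Where it says the series, first, only, none or still open, it means among the compounds named here.

Compound 3 `COc1cccc(/C=C/C(=O)c2ccc(OCc3ccccc3)cc2)c1` stands second highest of the three numbers in a functional assay on HCT-116 cells (Homo sapiens) for antiproliferative activity, read by sulforhodamine B assay, with a stated time of 3 days, tested at 25 uM (on this read-out higher numbers stand for a stronger effect at the one concentration tested and lower numbers for a weaker effect), where compound 3 gives 35.4%. Compound 1 `Cc1ccc(COc2ccc(C(=O)/C=C/c3ccccc3)cc2)cc1` gives 4%, and compound 2 `O=C(/C=C/c1ccc(Cl)cc1)c1ccccc1` gives 97.5%, both gaps to compound 3 lying beyond the scatter. The change leading to compound 4 `O=C(/C=C/c1ccc(Cl)cc1)c1ccc(OCc2ccccc2)cc1` is 4-chlorophenyl in place of 3-methoxyphenyl on a double-bonded chain carbon bound to a double-bonded chain carbon. Among the compounds with values here, no measured pair with a single difference is available, so the step can only be estimated. A step upward in this assay of a number 29.6 percentage points higher from compound 3 to compound 4 (beyond the scatter) is expected, larger than the scatter. Compound 4 is expected to give 65%, in a range from 30% to 95%, because compound 2 gives 97.5% while carrying the same 4-chlorophenyl.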

Compound 4, a percentage reported as inhibition, at one concentration (the size of the read-out at that concentration, not a potency): 0.3%
Beside the measured number, compound 4's estimate is 64.7 percentage points above it, and the stated range ends above it.
By their numbers in this assay, from the lowest: compounds 4 and 1 (each within the scatter of the next); then compound 3; then compound 2.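

In this assay, 4-chlorophenyl in place of 3-methoxyphenyl on a double-bonded chain carbon bound to a double-bonded chain carbon gives a number 35.1 percentage points lower from compound 3 to compound 4 (beyond the scatter), so with benzyloxy present, 4-chlorophenyl does not bring the high read-out seen in compound 2. Benzyloxy in place of hydrogen on an aromatic carbon gives a number 97.2 percentage points lower from compound 2 to compound 4 (beyond the scatter), so the read-out with 4-chlorophenyl depends heavily on what this aromatic carbon carries. Nothing at hand explains either step. Going by these compounds, whether methoxy or an amine in place of benzyloxy on this aromatic carbon would keep the read-out of compound 2 stays open.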